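The source may report more compounds than this note shows. Statements on the series, on what has been measured and on what is new or still open speak of the compounds shown alone.

Three sulfonamides built on one shared core have been tested in a functional assay on Bel-7402 cells (Homo sapiens) for antiproliferative activity, read by sulforhodamine B assay, tested at 100 ug/mL; a lower number here means less inhibition, a higher number more inhibition at the concentration tested (going by the name of the read-out). Compound 1 `O=C1CCCCC1S(=O)(=O)Nc1ccccc1Br` gives 22.1%. The nearest number belongs to compound 2 `O=C1CCCCC1S(=O)(=O)Nc1ccc(Cl)cc1C(F)(F)F`, which gives 21%, a gap within the usual scatter, so the two cannot be told apart. Compound 3 `O=C1CCCCC1S(=O)(=O)Nc1cc(C(F)(F)F)cc(C(F)(F)F)c1` gives 66.9%, a gap from compound 1 that lies well beyond the scatter. Going by the values given here, no pair of measured compounds differs in a single place, so no measured step is available to guide an estimate. Compound 4 `O=C1CCCCC1S(=O)(=O)Nc1ccccc1Cl` is the untested analogue; the change from compound 1 is chloro in place of bromo on an aromatic carbon. Such a swap of one halogen for another is expected to move this assay little, so the step of a number 2.1 percentage points lower from compound 1 to compound 4 (within the scatter) is expected to stay within the scatter. Compound 4 is therefore estimated at 20%, between 8% and 35%.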

Compound 4, a percentage reported as inhibition, at one concentration (the size of the read-out at that concentration, not a potency): 1.98%
The estimate for compound 4 lay 18 percentage points above the measured number, and the stated range ends above it.
By their numbers in this assay, from the lowest: compound 4; then compounds 2 and 1 (each within the scatter of the next); then compound 3.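

In this assay, chloro in place of bromo on this aromatic carbon gives a number 20.1 percentage points lower from compound 1 to compound 4 (beyond the scatter) and so shows that the choice of halogen here can change the inhibition read at this concentration. Going by these compounds alone, this is the only comparison in the set in which just one place differs, so it is the first direct reading of a change at this position. Nothing available explains the step.

Still open, from the compounds shown here alone, is how a fluoro, a methyl or an amine on this carbon would compare with chloro and bromo. Also open, going by these compounds, is whether the same halogen swap would give a similar step elsewhere on the aromatic ring.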